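Hydroxymethyl for hydroxy on the aryl thiourea series

The source may hold more compounds than are shown below. What is called first, only, known or untested is meant among the compounds shown, and "the series" means these compounds.

Working notes on three measured thioureas and one open analogue. Compound 1 `S=C(Nc1ccccc1)Nc1ccc2[nH]ccc2c1` gives 81.4% in an ADME assay on isolated protein for inhibition of peroxidase (Raphanus sativus), read by fluorescence and Amplex Red, tested at 5 uM; on this read-out lower numbers stand for a stronger effect and higher numbers for a weaker effect at the one concentration tested. Compound 2 `Oc1ccccc1NC(=S)Nc1ccc2[nH]ccc2c1` gives 43.9% in this assay, and compound 3 `Oc1ccc(NC(=S)Nc2ccc3[nH]ccc3c2)cc1` gives 41.5%. Compound 3 and compound 2 sit within the scatter of each other, while both lie far from compound 1: the change to hydroxy gave a number 37.5 percentage points lower from compound 1 to compound 2 (beyond the scatter) and, at the other position, a number 39.9 percentage points lower from compound 1 to compound 3 (beyond the scatter).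

Compound 4 `OCc1ccc(NC(=S)Nc2ccc3[nH]ccc3c2)cc1` is not yet measured. It differs from compound 3 by hydroxymethyl in place of hydroxy on an aromatic carbon. Going by the values given here, no measured step swaps hydroxy for hydroxymethyl, so the two hydroxy steps are the only guide: each pulled the number well down from compound 1, and the entering group keeps one hydrogen-bond donor and one hydrogen-bond acceptor. The expectation is that compound 4 lands between compound 1 and compound 3, with a step of a number 18.5 percentage points higher from compound 3 to compound 4 (beyond the scatter) upward from compound 3 that is expected to reach beyond the scatter. The estimate for compound 4 in this assay is 60%, within a range of 40% to 85%.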

Compound 4, a percentage reported as activity, at one concentration (the size of the read-out at that concentration, not a potency): 88.3%
For compound 4 the middle estimate is 28.3 percentage points below the measured one, and the stated range ends below it.
By their numbers in this assay, from the lowest: compounds 3 and 2 (each within the scatter of the next); then compounds 1 and 4 (each within the scatter of the next).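

In this assay the result of hydroxy at this position, para to a large group, does not carry over to hydroxymethyl: the swap gives a number 46.8 percentage points higher from compound 3 to compound 4 (beyond the scatter) and so separates two groups with the same hydrogen-bond donor and acceptor counts. Set against hydrogen, hydroxymethyl gives a number 6.9 percentage points higher from compound 1 to compound 4 (within the scatter) and thus shows no effect on this read-out, which means those counts alone do not account for the numbers of compound 1, compound 3 and compound 4. No measurement available explains the difference between hydroxy and hydroxymethyl.

On these data alone, whether an amine or a methoxy group on the same aromatic carbon would follow compound 3 or compound 4 remains open. Also open, as far as these compounds go, is whether hydroxymethyl would give the same result at the hydroxy position of compound 2.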